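Amino in place of chloro: expected cytotoxicity of compound 4

A few compounds are considered here, and "the series" means these few. Any claim that something is new, unique, unknown or untested is made for them only; others in the source may bear on it.

Within the data shown here, compound 2 `ClCc1cccc(Cn2cnc3c(Cl)nc(Cl)nc32)c1` carries the only single number reported in a functional assay on SF-268 cells (Homo sapiens) for cytotoxicity, read by sulforhodamine B assay, with a stated time of 48 h; a lower number here means that less compound is tolerated, a higher number that more compound is tolerated: compound 2 gives 70800 nM. Compound 1 `ClCc1cccc(Cn2cnc3c(Cl)ncnc32)c1` reaches only a limit of the assay in this assay, and compound 1 gives > 100000 nM. Compound 3 `ClCc1cccc(Cn2cnc3nc(Cl)nc(Cl)c32)c1` has no result reported in this assay: compound 3 gives "not determined" (no result reported). Among the measured compounds shown here, the one measured step, an at least 1.4-fold lower number from compound 1 to compound 2 (0.14 log units; that floor lies within the scatter), puts chloro in place of hydrogen on an aromatic carbon, and its floor rests on (the limit of > 100000 nM in this assay, at which 1 of the 3 values shown sits). Compound 4 `Nc1nc(Cl)c2ncn(Cc3cccc(CCl)c3)c2n1` differs from compound 2 by amino in place of chloro on an aromatic carbon. For the measured compounds named here, no measured step exchanges chloro for amino, and the single step that is known stayed within the scatter, so no movement beyond the scatter is expected in this assay, in either direction. For compound 4 the expected value in this assay is estimated at 80000 nM, with a range from 30000 nM to 200000 nM. The step that this estimate implies, a 1.1-fold higher number from compound 2 to compound 4 (0.05 log units; within the scatter), is expected to stay within the scatter.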

Compound 4, concentration lethal to 50% of the cells: 67600 nM
Beside the measured number, compound 4's estimate is 1.2-fold (0.07 log units) above it, within the range that was stated.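

In this assay, exchanging chloro for amino on the aromatic carbon between two ring nitrogen atoms gives a 1.0-fold lower number from compound 2 to compound 4 (0.02 log units; within the scatter), so this position now shows a second substituent and the two cannot be told apart by this read-out. Set against hydrogen at the same position, amino gives an at least 1.4-fold lower number from compound 1 to compound 4 (0.17 log units; that floor lies within the scatter), and that floor, like the one for chloro, says little about the true size of the step: the limit of > 100000 nM in this assay, at which 1 of the 4 values shown sits. Amino is counted with 1 hydrogen-bond donor and 1 hydrogen-bond acceptor, chloro with neither, and this difference comes with no step beyond the scatter in this one pair.

The compounds shown leave open whether any group at this position, such as a dimethylamino or a methoxy group, would move the number beyond the scatter. They also leave open what a hydroxymethyl group in place of the chloromethyl group would do.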